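Working notes on a histamine series: compound 3 to compound 4

The source may hold more compounds than are shown below. What is called first, only, known or untested is meant among the compounds shown, and "the series" means these compounds.

Among the compounds with values here, in an assay for binding affinity to histamine H2 receptor (Homo sapiens) (on this read-out higher numbers stand for weaker inhibition and lower numbers for stronger inhibition), compound 3 `C[C@@H](NC(=O)OC(C)(C)C)C(=O)N1CCN(CCCOc2ccc(C(=O)C3CC3)cc2)CC1` gives 83200 nM, the highest number of the three compounds measured so far. Compound 2 `CCCCCC(=O)c1ccc(OCCCN2CCN(C(=O)[C@@H](C)NC(=O)OC(C)(C)C)CC2)cc1` gives 10700 nM, and compound 1 `CCCCCC(=O)c1ccc(OCCCN2CCN(C(=O)[C@@H](CC(C)C)NC(=O)OC(C)(C)C)CC2)cc1` gives 4470 nM. The two measured steps are a 2.4-fold higher number from compound 1 to compound 2 (0.38 log units; beyond the scatter) and a 7.8-fold higher number from compound 2 to compound 3 (0.89 log units; beyond the scatter), both beyond the scatter but modest in size.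

Compound 4 `CC(C)(C)OC[C@@H](N)C(=O)N1CCN(CCCOc2ccc(C(=O)C3CC3)cc2)CC1` has not yet been measured. It differs from compound 3 in one place: 1-amino-2-(tert-butoxy)ethyl in place of 1-((tert-butoxycarbonyl)amino)ethyl on a carbonyl carbon. Neither measured step repeats this change. The step from compound 1 to compound 2 altered the group on a saturated chain carbon of this same side chain and moved the number only modestly; the step from compound 2 to compound 3 concerned the group on the other carbonyl carbon, which is unchanged here. Within the data shown here, there is thus no direct precedent, and the expectation can rest only on the modest size of the one side-chain step seen.

For compound 4 a step of a 1.7-fold lower number from compound 3 to compound 4 (0.22 log units; within the scatter) is expected, with no firm direction and possibly within the scatter. Compound 4 is therefore estimated at 50000 nM, in the range 15000 nM to 170000 nM.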

Compound 4, inhibition constant: 45700 nM
Compound 4: the middle estimate sits 1.1-fold (0.04 log units) above what was measured; low and high end bracket the measured number.
By their numbers in this assay, from the lowest: compound 1; then compound 2; then compounds 4 and 3 (each within the scatter of the next).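

In this assay, exchanging 1-((tert-butoxycarbonyl)amino)ethyl for 1-amino-2-(tert-butoxy)ethyl on this carbonyl carbon gives a 1.8-fold lower number from compound 3 to compound 4 (0.26 log units; within the scatter), so on this read-out the two groups cannot be told apart, although the entering group has fewer heavy atoms than the leaving group and the counts of hydrogen-bond donors and acceptors are the same on both. Within the data shown here, this is the first replacement of the whole group at this place, and it stays within the scatter, whereas the earlier change inside the side chain, a 2.4-fold higher number from compound 1 to compound 2 (0.38 log units; beyond the scatter), lay beyond it on the pentyl background rather than the cyclopropyl one. No measurement bears on why this exchange leaves the number within the scatter.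

Going by these compounds, whether the same exchange would also stay within the scatter with pentyl in place of cyclopropyl on the other carbonyl carbon remains open, as the pair here carries cyclopropyl only. Also open, on these data alone, is what a carboxylic acid, a benzyl group or a longer chain would give at this place on the shared core, since the two groups compared here span only a narrow range of side chains.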